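The source may hold more compounds than are shown below. What is called first, only, known or untested is meant among the compounds shown, and "the series" means these compounds.

In a physicochemical assay for solubility (on this read-out higher numbers stand for higher solubility and lower numbers for lower solubility), compound 1 `O=S(=O)(Nc1nccs1)c1ccc2c(c1)OCC[C@H]2c1ccc(C(F)(F)F)cc1-c1nccs1` gives 7000 nM and compound 2 `O=S(=O)(Nc1nccs1)c1ccc2c(c1)OCC[C@H]2c1ccc(C(F)(F)F)cc1-n1ccnn1` gives 154000 nM while compound 3 `O=S(=O)(Nc1nccs1)c1ccc2c(c1)OCC[C@@H]2c1ccc(C(F)(F)F)cc1-c1ccc(F)cc1` gives 39000 nM and so stands second highest of the three. Compound 4 `O=S(=O)(Nc1nccs1)c1ccc2c(c1)OCC[C@H]2c1ccc(C(F)(F)F)cc1-c1ccc(F)cc1` has no number yet. The change from compound 3 to compound 4 is the two compounds have the same atoms and bonds and differ only in configuration as drawn: 1 of 1 stereo elements differ; a stereocentre at a saturated ring carbon is drawn R in compound 3 and S in compound 4 and nothing else: the two have the same atoms and bonds, with a stereocentre at a saturated ring carbon drawn R in compound 3 and S in compound 4. Within the data shown here, the only measured step is a 22-fold higher number from compound 1 to compound 2 (1.34 log units; beyond the scatter) and it is large, but it puts 1H-1,2,3-triazol-1-yl in place of 1,3-thiazol-2-yl and involves no change of configuration. Among the measured compounds shown here, no measured pair shows a change of configuration alone, so no shift beyond the scatter is expected in this assay for this pair. The estimated step is no change at the digits printed from compound 3 to compound 4 (within the scatter) for this change. Compound 4 is expected at 39000 nM with an estimated range from 16000 nM to 95000 nM on this read-out.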

Compound 4, solubility: 147000 nM
Beside the measured number, compound 4's estimate is 3.8-fold (0.58 log units) below it; measured number outside the range, above it.
By their numbers in this assay, from the lowest: compound 1; then compound 3; then compounds 4 and 2 (each within the scatter of the next).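

In this assay, the configuration at this saturated ring carbon matters by itself, with a 3.8-fold higher number from compound 3 to compound 4 (0.58 log units; beyond the scatter), and that shift can be assigned to the stereocentre alone because of one fact: the fact that compounds 3 and 4 differ only in the configuration as drawn. With the stereocentre drawn S, 4-fluorophenyl in place of 1H-1,2,3-triazol-1-yl gives a 1.0-fold lower number from compound 2 to compound 4 (0.02 log units; within the scatter), while 4-fluorophenyl in place of 1,3-thiazol-2-yl gives a 21-fold higher number from compound 1 to compound 4 (1.32 log units; beyond the scatter). Among these three S compounds, only compound 1 stands apart.

From the compounds shown here alone, it remains open whether inverting the stereocentre has a similar effect when 1,3-thiazol-2-yl or 1H-1,2,3-triazol-1-yl occupies that aromatic carbon. Where an amine or a carboxylic acid on that carbon would fall is also open.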